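A carbamoyl group added to compound 1

The compounds below may be only part of what the source reports. "The series", "measured", "known", "first", "only" and "open" are said of these compounds alone.

Compound 1 `CCOc1ccc(-c2cc3c(cn2)[nH]c(=O)n3-c2cc(OC)c(OC)c(OC)c2)cc1`: 5300 nM
Compound 2 `CCOc1ccc(-c2cc3c(cn2)[nH]c(=O)n3-c2cc(OC)c(OC)c(OC)c2)cc1F`: 2540 nM
Compound 3 `CCOc1ccc(-c2cc3c([nH]c(=O)n3-c3cc(OC)c(OC)c(OC)c3)c(C(N)=O)n2)cc1`: not yet measured

In a functional assay on A549 cells (Homo sapiens) for antiproliferative activity, read by MTT assay, with a stated time of 48 h (a higher number here means a weaker inhibitor, a lower number a stronger inhibitor), compound 1 gives 5300 nM, the higher of the two numbers available. Compound 3 differs from it by a single change, carbamoyl in place of hydrogen on an aromatic carbon. Among the measured compounds shown here, only one measured step is available, a 2.1-fold lower number from compound 1 to compound 2 (0.32 log units; beyond the scatter), a modest change that comes from fluoro in place of hydrogen on an aromatic carbon. For the measured compounds named here, that step involves another group in another place, so it offers only weak guidance, and no measured compound carries a carbamoyl. No clear direction can therefore be drawn for this assay, and no shift beyond the scatter is expected. The expected change is a 1.2-fold lower number from compound 1 to compound 3 (0.07 log units; within the scatter). For compound 3 the estimated value is 4500 nM, with an expected range of 900 nM to 22000 nM.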

Compound 3, half-maximal inhibitory concentration: 20700 nM
Estimate against measurement, compound 3: 4.6-fold (0.66 log units) below, and the stated range covers the measured number.
By their numbers in this assay, from the lowest: compound 2; then compound 1; then compound 3.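

In this assay the carbamoyl on the aromatic carbon next to the ring nitrogen gives a 3.9-fold higher number from compound 1 to compound 3 (0.59 log units; beyond the scatter) and so weakens the compound modestly, which shows that the activity of compound 1 responds to a change at this position. The only other step shown, a 2.1-fold lower number from compound 1 to compound 2 (0.32 log units; beyond the scatter) for a fluoro in another place, runs in the opposite direction, so the two changes to compound 1 do not share one trend. No measurement shown accounts for this shift.

Going by these compounds, it remains open whether this weakening belongs to the carbamoyl itself or would follow any group on this carbon, a question that a methyl, a nitrile or a carboxylic acid there could help settle. Also open, on these data alone, is how the carbamoyl would act alongside the fluoro of compound 2.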